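The compounds below may be only part of what the source reports. "The series", "measured", "known", "first", "only" and "open" are said of these compounds alone.

Compound 2 `CC[C@H](C)[C@H](N)CN(C(=O)[C@@H]1C[C@H]1C1CCCCC1)c1ccc(-c2ccccc2)cc1` and compound 1 `CC[C@H](C)[C@H](N)CN(C(=O)[C@@H]1C[C@H]1c1cccc(F)c1)c1ccc(-c2ccccc2)cc1` share one core and differ only in the group sitting on a saturated ring carbon of the three-membered ring. In a functional assay for agonist activity at G protein-coupled receptor 88 (Homo sapiens), read by HTRF and cAMP accumulation (on this read-out lower numbers stand for an effect already at smaller amounts and higher numbers for an effect only at larger amounts of compound), compound 1 gives 560 nM. For compound 2 this assay reports only a limit, > 25000 nM, so its true number is not known. The step of an at least 44-fold higher number from compound 1 to compound 2 (1.64 log units; beyond the scatter) shows that exchanging the 3-fluorophenyl for a cyclohexyl costs a great deal of potency; because of the limit of > 25000 nM in this assay, at which 1 of the 2 values shown sits, only a lower bound on that loss can be stated. Compound 3 `CC[C@H](C)[C@H](N)CN(C(=O)[C@@H]1C[C@H]1c1cc(F)cc(F)c1)c1ccc(-c2ccccc2)cc1` is not yet measured; it differs from compound 2 by 3,5-difluorophenyl in place of cyclohexyl on a saturated ring carbon. This change brings back a fluorinated aromatic ring of the kind compound 1 carries. Among the compounds with values here, the only measured step bearing on it is an at least 44-fold higher number from compound 1 to compound 2 (1.64 log units; beyond the scatter), read in reverse, so a large gain is expected, back toward where compound 1 stands, though the exact size cannot be fixed from a limit. Compound 3 is expected to give about 600 nM in this assay, most likely between 150 nM and 3000 nM, which would mean an at least 41-fold lower number from compound 2 to compound 3 (1.61 log units; beyond the scatter).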

Compound 3, half-maximal effective concentration: 960 nM
Beside the measured number, compound 3's estimate is 1.6-fold (0.20 log units) below it; the range from low to high includes it.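

In this assay, the change from cyclohexyl to 3,5-difluorophenyl on this saturated ring carbon gives an at least 26-fold lower number from compound 2 to compound 3 (1.41 log units; beyond the scatter), so a second fluorinated phenyl ring now stands against the cyclohexyl, and the earlier contrast no longer rests on compound 1 alone. Adding a further fluoro to the aromatic ring gives a 1.7-fold higher number from compound 1 to compound 3 (0.23 log units; within the scatter), which means that 3-fluorophenyl and 3,5-difluorophenyl cannot be told apart on this read-out, and the extra fluoro shows no measurable effect here. Compound 2 has only a limit and not a true number, so the size of the gain can be given only as a lower bound, because of this: the limit of > 25000 nM in this assay, at which 1 of the 3 values shown sits.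

On these data alone, what stays open is whether the gain comes from the aromatic ring itself or from the fluorine it carries, as both change together in this step; a plain phenyl or a difluorocyclohexyl at this place would separate the two. Also open, as far as these compounds go, is how far the aromatic ring tolerates other groups, such as a chloro, a methoxy, a nitrile or an amine, in place of fluoro.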